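The source may report more compounds than this note shows. Statements on the series, on what has been measured and on what is new or still open speak of the compounds shown alone.

Among the measured compounds shown here, the series so far holds two measured compounds, compound 1 `CCn1c([C@@H](C)NS(=O)(=O)c2ccc(C#N)cc2)nc2cnc(OC)cc21` and compound 2 `CCn1c([C@@H](C)NS(=O)(=O)c2ccc(C#N)cc2)nc2cnc(C3CC3)cc21`, both tested in a physicochemical assay for lipophilicity, at pH 7.4; on this read-out higher numbers stand for higher lipophilicity and lower numbers for lower lipophilicity. Compound 1 gives 1.4 and compound 2 gives 1.9, so compound 1 holds the lower of the two numbers.

The next structure is compound 3 `CCn1c([C@@H](C)NS(=O)(=O)c2ccc(C#N)nc2)nc2cnc(OC)cc21`, which differs from compound 1 on a sulfonyl sulfur (6-cyanopyridin-3-yl in place of 4-cyanophenyl on a sulfonyl sulfur). In words, 6-cyanopyridin-3-yl stands in place of 4-cyanophenyl.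

For the measured compounds named here, only one measured step is available (a number 0.50 log units higher from compound 1 to compound 2 (beyond the scatter)), where cyclopropyl replaces methoxy on an aromatic carbon. Going by the values given here, that step is modest and sits at a different place in the molecule, so it offers a sense of scale and no direct precedent. Among the compounds with values here, no measured pair tests the new swap itself.

From the compounds shown here alone, a step of similar size is expected in this assay, going downward as a hetero atom enters the ring, although this direction remains untested here. The expected change is a number 0.50 log units lower from compound 1 to compound 3 (beyond the scatter) (an estimate). For compound 3 the estimated value is 0.9 (expected range 0.5 to 1.3).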

Compound 3, distribution coefficient: 1
Beside the measured number, compound 3's estimate is 0.10 log units below it, within the range that was stated.
By their numbers in this assay, from the lowest: compound 3; then compound 1; then compound 2.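

Among the compounds shown here, this result is the first measured change on the sulfonyl sulfur, and it shows that this part of the molecule also moves the number in this assay: 6-cyanopyridin-3-yl in place of 4-cyanophenyl gives a number 0.40 log units lower from compound 1 to compound 3 (beyond the scatter). The two groups have the same count of heavy atoms, and the nitrile stays in both, yet a ring of carbon only giving way to a ring with a hetero atom is enough for a change beyond the usual scatter, in the opposite direction to the earlier step at the other place, a number 0.50 log units higher from compound 1 to compound 2 (beyond the scatter). Why the number falls with this swap remains unexplained, as no measurement bearing on the cause is available.

The compounds shown leave open whether the same swap would give a step of similar size with cyclopropyl on the aromatic carbon, as in compound 2, rather than with the methoxy group of compound 1. They also leave open how the number in this assay would respond if a carboxylic acid or an amine stood on the ring in place of the nitrile.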